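Sulfonamide in place of the dimethylurea on the aminomethyl arm

The source may hold more compounds than are shown below. What is called first, only, known or untested is meant among the compounds shown, and "the series" means these compounds.

Measured compounds:
- compound 1, `CCCCc1ccc(CNC(=O)NC2CCCCC2)c(=O)n1Cc1ccc(-c2ccccc2-c2nn[nH]n2)cc1`: 90 nM
- compound 2, `CCCCc1ccc(CNC(=O)N(C)C)c(=O)n1Cc1ccc(-c2ccccc2-c2nn[nH]n2)cc1`: 2 nM
- compound 3, `CCCCc1ccc(CN(Cc2ccccc2)S(=O)(=O)c2ccc(C)cc2)c(=O)n1Cc1ccc(-c2ccccc2-c2nn[nH]n2)cc1`: 60 nM

All three share one core and differ only in the group carried on the saturated chain carbon bound to an aromatic carbon. In a functional assay (aorta) for antagonist activity, with Oryctolagus cuniculus as the target (on this read-out higher numbers stand for weaker inhibition and lower numbers for stronger inhibition), compound 2 gives the lowest number of the three with 2 nM; the step of a 45-fold lower number from compound 1 to compound 2 (1.65 log units; beyond the scatter) separates it from compound 1, and compound 3 stands between them with 60 nM.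

Compound 4, `CCCCc1ccc(CN(C)S(=O)(=O)c2ccccc2)c(=O)n1Cc1ccc(-c2ccccc2-c2nn[nH]n2)cc1`, is not yet measured. The change is methyl(phenylsulfonyl)amino in place of (dimethylcarbamoyl)amino on a saturated chain carbon bound to an aromatic carbon. For the measured compounds named here, the only step measured at this position is the one from the cyclohexylurea to the dimethylurea, a 45-fold lower number from compound 1 to compound 2 (1.65 log units; beyond the scatter), which shows that this arm moves the read-out strongly. Going by the values given here, no step to compound 4 is measured; the nearest reference is compound 3, a sulfonamide that reads well above compound 2. A sulfonamide in place of the dimethylurea is therefore expected to raise the number, though compound 4 is smaller than compound 3 and may not lose as much.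

Expected step: a 15-fold higher number from compound 2 to compound 4 (1.18 log units; beyond the scatter). Compound 4 is estimated at 30 nM in this assay, within 8 nM to 120 nM.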

Compound 4, half-maximal inhibitory concentration: 2 nM
For compound 4 the middle estimate is 15-fold (1.18 log units) above the measured one; measured number outside the range, below it.
By their numbers in this assay, from the lowest: compounds 2 and 4 (each within the scatter of the next); then compounds 3 and 1 (each within the scatter of the next).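

In this assay, the arm carried on the saturated chain carbon bound to an aromatic carbon does not need a urea: methyl(phenylsulfonyl)amino stands in for (dimethylcarbamoyl)amino with no shift in the read-out (no change at the digits printed from compound 2 to compound 4 (within the scatter)). This swap removes the hydrogen-bond donor of the urea and adds a six-membered aromatic ring, so neither feature is required for a low number in this pair, and the larger group is accepted here. The sulfonamide also keeps the full gain over the cyclohexylurea (a 45-fold lower number from compound 1 to compound 4 (1.65 log units; beyond the scatter)), so a large drop in the number is no longer tied to the dimethylurea alone, although no measurement here explains why these two different groups read alike.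

Compound 3 differs from compound 4 in more than one place, so its higher number cannot be assigned to the benzyl group on the sulfonamide nitrogen or to the methyl on the aromatic ring taken alone; single changes, such as benzyl in place of methyl on that nitrogen, would separate the two. From the compounds shown here alone, it also remains open whether this arm accepts a simple amine or a carboxylic acid, or whether a sulfonamide carrying hydrogen on its nitrogen reads like compound 4.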